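A Halogen Swap on the Benzyl Group of Compound 1

The source may hold more compounds than are shown below. What is called first, only, known or untested is meant among the compounds shown, and "the series" means these compounds.

Compound 1 `OC[C@@]1(O)CO[C@@H](n2cnc3c(NCc4cccc(Cl)c4)ncnc32)[C@@H]1O` is the starting point of this account. In an assay on CHO cells for displacement of a labelled ligand from adenosine receptor A1 (Homo sapiens), tested at 10 uM (a higher number here means more inhibition at the concentration tested (going by the name of the read-out), a lower number less inhibition), compound 1 gives 10%. Two other members of the set were run alongside it: compound 2 `CCNC(=O)[C@@H]1CO[C@@H](n2cnc3c(N)ncnc32)[C@@H]1O` gives 8% in this assay, and compound 3 `CNC(=O)OC[C@@]1(O)CO[C@@H](n2cnc3c(N)ncnc32)[C@@H]1O` gives 12% in this assay. Compound 1 sits in the middle of these three numbers, yet its gaps to compound 2 and to compound 3 both lie within the usual scatter, so the three values read as the same low level of inhibition rather than as an order. Among the measured compounds shown here, no two of the measured compounds differ in a single place, so no step can be drawn from them.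

Compound 4 `OC[C@@]1(O)CO[C@@H](n2cnc3c(NCc4cccc(I)c4)ncnc32)[C@@H]1O` has not yet been measured. Relative to compound 1 the change is iodo in place of chloro on an aromatic carbon, sitting meta to a large group. For the measured compounds named here, with no measured step to lean on and the three known values all close together, the account expects no change beyond the scatter in this assay, a step of a number 5 percentage points higher from compound 1 to compound 4 (within the scatter). Compound 4 is therefore estimated at 15%, within a range of 2% to 32%.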

Compound 4, a percentage reported as inhibition, at one concentration (the size of the read-out at that concentration, not a potency): 27%
Compound 4: middle estimate off by 12 percentage points, on the low side; low and high end bracket the measured number.
By their numbers in this assay, from the lowest: compounds 2, 1 and 3 (each within the scatter of the next); then compound 4.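

The exchange of chloro for iodo on the aromatic carbon gives the first difference in this assay that stands clear of the scatter, with a number 17 percentage points higher from compound 1 to compound 4 (beyond the scatter) as the step. Among the compounds shown here, it shows that the read-out responds to what sits at this place on the 3-chlorobenzyl group, which compounds 1, 2 and 3, at one level and with no step among them, could not reveal. Even so, compound 4 gives only 27%, the size of the read-out at one concentration and not a potency, and nothing at hand explains the step.

As far as these compounds go, it remains open whether bromo at this place would give a number between those of the chloro and iodo compounds, or whether the rise belongs to iodo alone. Equally open, from the compounds shown here alone, is how a methyl, methoxy or longer alkyl chain would read in its stead.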